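The compounds below may be only part of what the source reports. "The series", "measured", "known", "first", "only" and "open" are said of these compounds alone.

Measured so far:
- compound 1, `COc1cc(/C=C/C(=O)c2cccc(-n3cc(-c4ccccc4)[nH]c3=O)c2)ccc1O`: 1910 nM
- compound 2, `COc1cc(/C=C/C(=O)c2cccc(-n3cc(-c4cc(OC)c(OC)c(OC)c4)[nH]c3=O)c2)cc(OC)c1OC`: 3120 nM

Both compounds were tested in a functional assay on SF-539 cells (Homo sapiens) for inhibition; on this read-out lower numbers stand for stronger inhibition of growth and higher numbers for weaker inhibition of growth. Compound 1 gives 1910 nM, the lower of the two numbers, while compound 2 gives 3120 nM; the two values lie within the scatter of each other, so the data do not separate them. Among the compounds with values here, the two compounds differ at more than one place, so no single step between them is counted here.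

Compound 3, `COc1cc(/C=C/C(=O)c2cccc(-n3cc(-c4ccc(Cl)cc4)[nH]c3=O)c2)ccc1O`, has not yet been measured in this assay. It differs from compound 1 in one place: chloro in place of hydrogen on an aromatic carbon. Put simply, a chloro group replaces a hydrogen on an aromatic carbon of a six-membered carbon-only ring, para to a large group; one bond further out, the change reads phenyl to 4-chlorophenyl.

Within the data shown here, no measured pair shows what such a change does in this assay, so there is no counted step to lean on. On that basis the expectation for compound 3 is a step from compound 1 of a 1.2-fold lower number from compound 1 to compound 3 (0.08 log units; within the scatter), not beyond the scatter in either direction. Compound 3 is therefore estimated at 1600 nM, with a range from 500 nM to 5000 nM.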

Compound 3, concentration for 50% growth inhibition: 1780 nM
Beside the measured number, compound 3's estimate is 1.1-fold (0.05 log units) below it; measured number inside the range.
By their numbers in this assay, from the lowest: compounds 3, 1 and 2 (each within the scatter of the next).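

The single-place comparison in this assay comes from compounds 1 and 3: turning phenyl into 4-chlorophenyl, with chloro in place of hydrogen on an aromatic carbon para to a large group, gives a 1.1-fold lower number from compound 1 to compound 3 (0.03 log units; within the scatter). At this position, then, adding a single chlorine atom produces no difference that the data can distinguish from ordinary repeat-to-repeat variation, so compound 1 and compound 3 cannot be separated. Nothing presented here offers an explanation for this outcome.

From the compounds shown here alone, this one substitution shows only how chloro compares with hydrogen at this place, so it remains open whether a carboxylic acid, an amine or a longer chain there would also stay within the scatter of compound 1. It also remains open whether chloro would give a similarly small step on an aromatic carbon elsewhere in the molecule, since the compounds shown test this change at only one position.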